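The source may report more compounds than this note shows. Statements on the series, on what has been measured and on what is new or still open speak of the compounds shown alone.

Of the compounds shown here, three sharing one core have been tested in an assay on CHO cells for displacement of a labelled ligand from adenosine receptor A1 (Homo sapiens), read by scintillation counting, with a stated time of 120 min, tested at 1 uM; a higher number here means more inhibition at the concentration tested (going by the name of the read-out), a lower number less inhibition. Compound 1 `Cc1nc(NC(=O)c2ccccc2)c2nn(-c3ccccc3)cc2n1` gives 30%, compound 2 `Cc1nc(NC(=O)Nc2ccccc2)c2nn(-c3ccccc3)cc2n1` gives 1% and compound 3 `Cc1nc(NC(=O)c2ccco2)c2nn(-c3ccccc3)cc2n1` gives 20%. Compound 3 thus stands second of the three: its value sits within the scatter of compound 1, while a number 19 percentage points higher from compound 2 to compound 3 (beyond the scatter) lies beyond it. Compound 4 `COc1ccc(C(=O)Nc2nc(C)nc3cn(-c4ccccc4)nc23)cc1` differs from compound 3 by 4-methoxyphenyl in place of furan-2-yl on a carbonyl carbon. The most telling step is a number 10 percentage points lower from compound 1 to compound 3 (within the scatter), showing that a six-membered carbon ring and the furan-2-yl ring give values within the scatter of each other. Compound 4 is therefore expected to land near compound 1, with a number 10 percentage points higher from compound 3 to compound 4 (within the scatter). The estimate for compound 4 is 30%, within 10% to 50%.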

Compound 4, a percentage reported as inhibition, at one concentration (the size of the read-out at that concentration, not a potency): 4%
The estimate for compound 4 lay 26 percentage points above the measured number; measured number outside the range, below it.
By their numbers in this assay, from the lowest: compounds 2 and 4 (each within the scatter of the next); then compounds 3 and 1 (each within the scatter of the next).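

In this assay, methoxy in place of hydrogen on an aromatic carbon gives a number 26 percentage points lower from compound 1 to compound 4 (beyond the scatter), so a single added group on the phenyl ring matters here, whereas swapping that ring for furan-2-yl did not give a change beyond the scatter. Against furan-2-yl, 4-methoxyphenyl gives a number 16 percentage points lower from compound 3 to compound 4 (beyond the scatter), and against anilino it gives a number 3 percentage points higher from compound 2 to compound 4 (within the scatter). No available data explain these differences. As far as these compounds go, whether the drop is specific to methoxy or follows from any added group on this ring remains open. A chlorine atom or an amine in place of methoxy could help separate these possibilities.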